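The compounds below may be only part of what the source reports. "The series", "measured", "known", "first", "only" and "open" are said of these compounds alone.

Series notes. Compound 1 `COc1nc(-c2cc3ccccc3o2)cc(-c2ccc(Cl)cc2)c1C#N` is measured in a functional assay on aorta (strain Wistar) for inhibition, with Thoracic aorta (Rattus norvegicus) as the target (on this read-out lower numbers stand for stronger inhibition and higher numbers for weaker inhibition), at 286000 nM. Compound 2 `CCOc1nc(-c2cc3ccccc3o2)cc(-c2ccc(Cl)cc2)c1C#N` differs from compound 1 by methyl in place of hydrogen on a saturated chain carbon bound to an oxygen on an aromatic ring; in this assay compound 2 gives 221000 nM, a step of a 1.3-fold lower number from compound 1 to compound 2 (0.11 log units; within the scatter). Compound 3 `COc1nc(-c2cc3ccccc3o2)cc(-c2ccc(N(C)C)cc2)c1C#N` has a different core; how the cores differ is dimethylamino in place of chloro on an aromatic carbon, and in this assay compound 3 gives 278000 nM, with a 1.0-fold lower number from compound 1 to compound 3 (0.01 log units; within the scatter). Compound 4 `CCOc1nc(-c2cc3ccccc3o2)cc(-c2ccc(N(C)C)cc2)c1C#N` is not yet measured; it differs from compound 3 by methyl in place of hydrogen on a saturated chain carbon bound to an oxygen on an aromatic ring. This is the same change as that from compound 1 to compound 2, made at the same place, and it is the only other instance of the change among these compounds. Because that earlier step stands at a 1.3-fold lower number from compound 1 to compound 2 (0.11 log units; within the scatter), the change is expected to carry over to the core of compound 3 at a similar small size: the step from compound 3 to compound 4 in this assay is expected to be a 1.3-fold lower number from compound 3 to compound 4 (0.11 log units; within the scatter), within the scatter as before. Compound 4 is thus estimated in this assay at 215000 nM, with a range from 100000 nM to 450000 nM.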

Compound 4, half-maximal inhibitory concentration: 338000 nM
Beside the measured number, compound 4's estimate is 1.6-fold (0.20 log units) below it; low and high end bracket the measured number.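

In this assay, the methoxy to ethoxy change gives a 1.2-fold higher number from compound 3 to compound 4 (0.08 log units; within the scatter), and this step does not differ from the one on the core of compound 1: the same change on two cores in this assay, a 1.3-fold lower number (0.11 log units; within the scatter) from compound 1 to compound 2 and a 1.2-fold higher number (0.08 log units; within the scatter) from compound 3 to compound 4, 1.6-fold (0.20 log units) apart, within the scatter of two such steps. Dimethylamino in place of chloro on an aromatic carbon, read on the ethoxy compounds, gives a 1.5-fold higher number from compound 2 to compound 4 (0.18 log units; within the scatter), and this step does not differ from the one read on the methoxy compounds either: the same change on two cores in this assay, a 1.0-fold lower number (0.01 log units; within the scatter) from compound 1 to compound 3 and a 1.5-fold higher number (0.18 log units; within the scatter) from compound 2 to compound 4, 1.6-fold (0.20 log units) apart, within the scatter of two such steps. Within the four compounds, each change therefore carries from one core to the other without a difference that can be read, but every step lies within the scatter, so this shows no real effect of either change and cannot establish a shared size or direction, nor exclude a small dependence on the core.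

From the compounds shown here alone, it remains open whether a longer chain such as propoxy in place of ethoxy would give a step beyond the scatter. The same holds for an amine or a carboxylic acid in place of chloro on an aromatic carbon, and for whether such a step would carry between these cores.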